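The compounds below may be only part of what the source reports. "The series", "measured", "known", "first", "only" and "open" are said of these compounds alone.

Measured compounds:
compound 1 `CCOc1c(-c2cc(OC)c(OC)c(OC)c2)oc2ccccc2c1=O` — 900 nM
compound 2 `CCCCOc1c(-c2cc(OC)c(OC)c(OC)c2)oc2ccccc2c1=O` — 12800 nM

In a functional assay on PC-3 cells (Homo sapiens) for antiproliferative activity, read by WST assay, with a stated time of 3 days (on this read-out lower numbers stand for stronger inhibition and higher numbers for weaker inhibition), compound 1 gives 900 nM, the lowest of the two numbers shown; its nearest neighbour is compound 2, which gives 12800 nM. Compound 3 `CCC(C)Oc1c(-c2cc(OC)c(OC)c(OC)c2)oc2ccccc2c1=O` has not yet been measured. It differs from compound 1 by ethyl in place of hydrogen on a saturated chain carbon bound to an oxygen on an aromatic ring and a saturated chain carbon. For the measured compounds named here, only one measured step bears on this change: a 14-fold higher number from compound 1 to compound 2 (1.15 log units; beyond the scatter), where the same ethyl enters two bonds along the chain from an oxygen on an aromatic ring, rather than on the saturated chain carbon bound to an oxygen on an aromatic ring as in compound 3. Because of a 14-fold higher number from compound 1 to compound 2 (1.15 log units; beyond the scatter) a higher number for compound 3 than for compound 1 is expected in this assay, although the place of entry differs and the size of that step cannot simply be carried over. The step expected is a 5.6-fold higher number from compound 1 to compound 3 (0.74 log units; beyond the scatter). For compound 3 the estimate in this assay is 5000 nM, with a range from 1500 nM to 16000 nM.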

Compound 3, half-maximal inhibitory concentration: 38600 nM
Compound 3: the middle estimate sits 7.7-fold (0.89 log units) below what was measured; the measured number lies above the stated range.
By their numbers in this assay, from the lowest: compound 1; then compound 2; then compound 3.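

In this assay, the same ethyl does not read the same at both places: entering on the saturated chain carbon bound to the oxygen, it gives a 43-fold higher number from compound 1 to compound 3 (1.63 log units; beyond the scatter). The two larger groups also stand apart, with sec-butyl in place of butyl giving a 3.0-fold higher number from compound 2 to compound 3 (0.48 log units; beyond the scatter), so the place of entry on the chain counts as well as the added carbons. In these three compounds, ethoxy gives the lowest number, and no measurement shown here explains the difference between butyl and sec-butyl.

Going by these compounds, whether a methyl or an isopropyl on the same oxygen would stay close to compound 1 remains open. So does how a chain ending in an amine or a carboxylic acid would behave at this position, and whether any of these steps would carry over to another cell line.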